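The source may hold more compounds than are shown below. What is called first, only, known or untested is meant among the compounds shown, and "the series" means these compounds.

Measured compounds in a functional assay on HL-60 cells (Homo sapiens) for antiproliferative activity, read by XTT assay, with a stated time of 72 h; on this read-out higher numbers stand for weaker inhibition and lower numbers for stronger inhibition:
compound 1, `CNc1ncnc2c1c(-c1ccsc1)cn2[C@@H]1O[C@H](CO)[C@@H](O)[C@H]1O`: > 20000 nM; this is a limit of the assay, not a number.
compound 2, `O=c1[nH]cnc2c1c(-c1cc3ccccc3o1)cn2[C@@H]1O[C@H](CO)[C@@H](O)[C@H]1O`: > 20000 nM; this too is a limit of the assay, not a number.

Compound 2 stands at the limit of the assay, and compound 1 stands there as well, so that (the limit of > 20000 nM in this assay, at which 2 of the 2 values shown sit). Neither value is a number, and the two compounds cannot be placed in any order against each other on this read-out. The unmeasured compound 3, `O=c1[nH]cnc2c1c(-c1cccs1)cn2[C@@H]1O[C@H](CO)[C@@H](O)[C@H]1O`, differs from compound 2 in one place: thiophen-2-yl in place of 1-benzofuran-2-yl on an aromatic carbon. Among the compounds with values here, no step between two measured compounds exists in this set, so the size of this change cannot be read from any measured pair; the only fact available is that compound 2 gives a limit rather than a number. The expected step is a step that the limit leaves unreadable from compound 2 to compound 3, which is to say none beyond the scatter in either direction. Compound 3 is expected at 30000 nM, with a range of 8000 nM to 100000 nM, and most likely this assay will again report only a limit for compound 3 and no number.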

Compound 3, half-maximal inhibitory concentration: > 20000 nM
Compound 3 was reported as a limit; the forecaster's own chance of this, stated with the estimate: 75%; the middle value lies beyond the limit too.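

No new step can be read: compound 2 and compound 3 both stand only at a limit of the assay, so the change from 1-benzofuran-2-yl to thiophen-2-yl has no readable size. The compounds shown leave open how any of these groups on the shared core relates to antiproliferative activity, as every value sits at one limit: the limit of > 20000 nM in this assay, at which 3 of the 3 values shown sit.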